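A few compounds are considered here, and "the series" means these few. Any claim that something is new, unique, unknown or untested is made for them only; others in the source may bear on it.

Working notes on the series.

Compound 1 `Cn1cc(-c2ccc(C(F)(F)F)cc2)c2cc(F)c(C(=O)NS(=O)(=O)C3CC3)cc21` and compound 3 `Cn1cc(-c2ccc(C(F)(F)F)cc2)c2cc(F)c(C(=O)NS(C)(=O)=O)cc21` share one core; compound 2 `CC(C)COc1ccc(-c2cn(C)c3cc(C(=O)NS(C)(=O)=O)c(F)cc23)cn1` is built on a different core, and the difference between the two cores is not broken down here. Compound 4 `CC(C)COc1ccc(-c2cn(C)c3cc(C(=O)NS(=O)(=O)C4CC4)c(F)cc23)cn1` is the partner of compound 2 and has not yet been run.

In an ADME assay for permeability, using PAMPA, at pH 5.5 (a lower number here means that the compound crosses the layer more slowly, a higher number that the compound crosses the layer faster), compound 1 gives 1660 nm/s. In this assay compound 3 gives 712 nm/s. In this assay compound 2 gives 802 nm/s; the numbers of compound 2 and compound 3 sit within the scatter of one another, while compound 1 stands higher than both.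

One structural change has been measured within the set: cyclopropyl in place of methyl on a sulfonyl sulfur The result was a 2.3-fold higher number from compound 3 to compound 1 (0.37 log units; beyond the scatter). The same change is made from compound 2 to compound 4: cyclopropyl in place of methyl on a sulfonyl sulfur The place lines of the two changes read the same word for word, so this is the same change, now on the core of compound 2.

For compound 4 the step is expected to be a 2.1-fold higher number from compound 2 to compound 4 (0.33 log units; beyond the scatter). For the measured compounds named here, this rests on the single measured instance, a 2.3-fold higher number from compound 3 to compound 1 (0.37 log units; beyond the scatter), and on nothing else; the change has been seen only once and on another core, so the range is kept wide. Compound 4 is estimated at 1700 nm/s, expected to fall between 1000 nm/s and 2800 nm/s.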

Compound 4, apparent permeability: 851 nm/s
The estimate for compound 4 lay 2.0-fold (0.30 log units) above the measured number, outside the stated range (below it).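

In this assay, cyclopropyl in place of methyl on a sulfonyl sulfur gives a 1.1-fold higher number from compound 2 to compound 4 (0.03 log units; within the scatter), and the comparison with the earlier step reads: the same change on two cores in this assay, a 2.3-fold higher number (0.37 log units; beyond the scatter) from compound 3 to compound 1 and a 1.1-fold higher number (0.03 log units; within the scatter) from compound 2 to compound 4, 2.2-fold (0.34 log units) apart, within the scatter of two such steps.
For the compounds shown here, the two steps therefore cannot be told apart, so these data give no ground for saying that the core changes the size of this step, even though only the step on the core of compound 1 lies beyond the scatter. Going by these compounds alone, they also do not show that the change carries over reliably: there are only two matched pairs, and the pair on the core of compound 2 shows no step that can be separated from the scatter, so a real step on that core is neither established nor ruled out.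

The compounds shown leave open what an ethyl group, a longer chain or an amine on the sulfonyl sulfur would do in this read-out. They also leave open how the same change from methyl to cyclopropyl would behave on any third core, which is the kind of pair that would say more about whether it carries across the series.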